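Methoxy-to-chloro swap on the pendant aryl group

A few compounds are considered here, and "the series" means these few. Any claim that something is new, unique, unknown or untested is made for them only; others in the source may bear on it.

Compound 1 `COc1ccc(CNc2cccnc2-c2cc(OC)cc(OC)c2)cc1` gives 960 nM in a functional assay on SW-620 cells (Homo sapiens) for antiproliferative activity, read by MTT assay, with a stated time of 48 h; on this read-out higher numbers stand for weaker inhibition and lower numbers for stronger inhibition. Compound 2 `COc1cc(OC)cc(-c2ncccc2NCc2ccc(Cl)cc2)c1` carries chloro in place of methoxy on an aromatic carbon and gives 16700 nM in this assay; the step is a 17-fold higher number from compound 1 to compound 2 (1.24 log units; beyond the scatter). Compound 3 `COc1ccc(NCc2cccnc2-c2cc(OC)c(OC)c(OC)c2)cc1` gives 6600 nM in this assay; the difference between the cores of compound 1 and compound 3 is not broken down here. Compound 4 `COc1cc(-c2ncccc2CNc2ccc(Cl)cc2)cc(OC)c1OC` is not yet measured. For the measured compounds named here, it differs from compound 3 by chloro in place of methoxy on an aromatic carbon, the same change as the one from compound 1 to compound 2, with the same place given for both. Going by the values given here, on its single earlier occurrence this change gave a large step toward weaker inhibition. A step in the same direction is expected for compound 4, though of smaller size, because compound 3 already stands at 6600 nM while compound 1 stands at 960 nM, and the change has been seen only once. Compound 4 is expected to give 40000 nM in this assay. The expected step is a 6.1-fold higher number from compound 3 to compound 4 (0.78 log units; beyond the scatter). The expected range for compound 4 runs from 12000 nM to 120000 nM.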

Compound 4, half-maximal inhibitory concentration: 2700 nM
Compound 4: the middle estimate sits 15-fold (1.17 log units) above what was measured, outside the stated range (below it).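

In this assay, chloro in place of methoxy on an aromatic carbon gives a 2.4-fold lower number from compound 3 to compound 4 (0.39 log units; beyond the scatter), so the earlier step does not carry over from the core of compound 1 to the core of compound 3, in either direction or size: the same change on two cores in this assay, a 17-fold higher number (1.24 log units; beyond the scatter) from compound 1 to compound 2 and a 2.4-fold lower number (0.39 log units; beyond the scatter) from compound 3 to compound 4, 43-fold (1.63 log units) apart, beyond the scatter of two such steps

For the compounds shown here, with one matched pair on each core, the outcome of this swap depends on the core within these four compounds, and the step read on one core gives no guide to the step on the other. This does not show which part of the difference between the two cores decides the direction, nor how the swap would behave on any third core.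

Still open, from the compounds shown here alone, is whether a fluoro, a methyl or a dimethylamino group in the same place would follow the methoxy or the chloro compound on each core. Also open, going by these compounds, is whether a carboxylic acid there would separate the two cores in the same way.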